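Series notes: the step from compound 2 to compound 3

A few compounds are considered here, and "the series" means these few. Any claim that something is new, unique, unknown or untested is made for them only; others in the source may bear on it.

For the measured compounds named here, compound 2 `COc1ccc(Nc2nccc(-c3ccncc3)n2)cc1` stands lowest of the two numbers measured so far in a functional assay for inhibition, with Homo sapiens as the target; on this read-out lower numbers stand for stronger inhibition and higher numbers for weaker inhibition; in that read-out compound 2 gives 4200 nM. Going by the values given here, its only measured neighbour is compound 1 `COc1ccc(Nc2nccc(-c3ccsc3)n2)cc1`, and in this assay compound 1 gives 15600 nM. Among the compounds with values here, the single step between them, a 3.7-fold lower number from compound 1 to compound 2 (0.57 log units; beyond the scatter), concerns the aryl group attached to the shared core and leaves the aniline side untouched.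

Compound 3 `CC1CCN(c2ccc(Nc3nccc(-c4ccncc4)n3)cc2)CC1` differs from compound 2 on that other side: 4-methylpiperidin-1-yl in place of methoxy on an aromatic carbon. Within the data shown here, no measured step touches this position, so the step from compound 1 to compound 2 offers no guide to the size or direction of this change. The two measured values give no argument for a large move either way. Among the measured compounds shown here, the expected step in this assay is therefore a 1.7-fold lower number from compound 2 to compound 3 (0.23 log units; within the scatter), kept small and with a wide range, as no measured pair tests this change. For compound 3 the estimate in this assay is 2500 nM, expected to fall between 500 nM and 10000 nM.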

Compound 3, half-maximal inhibitory concentration: 600 nM
Beside the measured number, compound 3's estimate is 4.2-fold (0.62 log units) above it; the range from low to high includes it.
By their numbers in this assay, from the lowest: compound 3; then compound 2; then compound 1.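

Working notes on the aromatic carbon para to a large group: in this assay this position responds clearly to substitution, as 4-methylpiperidin-1-yl in place of methoxy gives a 7.0-fold lower number from compound 2 to compound 3 (0.85 log units; beyond the scatter) and so moves the number beyond the scatter. The pair of compound 1 and compound 2 varies only the aryl group on the shared core, whereas this step shows that the other side also affects the read-out and that a group of 7 heavy atoms with a six-membered non-aromatic ring is compatible with a lower number than the 2 heavy atoms of methoxy, with the same printed counts of hydrogen-bond donors and acceptors and no net charge on either group. Nothing available accounts for the size of this step.

The compounds shown do not separate the contributions of the ring, its nitrogen and its methyl group, so an unsubstituted piperidin-1-yl, a morpholin-4-yl, a piperazin-1-yl or an open-chain dimethylamino group at this position would each bear on that question. Also open, from the compounds shown here alone, is whether 4-methylpiperidin-1-yl gives a comparable step when thiophen-3-yl replaces pyridin-4-yl on the shared core.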